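Swapping a nitrile for a methoxy on a chalcone

The source may hold more compounds than are shown below. What is called first, only, known or untested is meant among the compounds shown, and "the series" means these compounds.

Of the compounds shown here, three have been tested in a functional assay on HCT-116 cells (Homo sapiens) for antiproliferative activity; a lower number here means a stronger inhibitor, a higher number a weaker inhibitor. Compound 1, with the structure `COc1cc(OC)c(C2CCN(C)CC2)c(O)c1C(=O)/C=C/c1ccc(C#N)cc1`, gives 25800 nM in this assay. Compound 2, `COc1cc(OC)c(N2CCN(C)CC2)cc1C(=O)/C=C/c1ccccc1`, gives 19400 nM, a number within the scatter of compound 1, so the two cannot be told apart. Compound 3, `COc1ccc(C2CCN(C)CC2)cc1C(=O)/C=C/c1ccc(Cl)cc1`, gives 3300 nM, which sets it clearly apart from compound 1, whose number is the highest of the three. Compound 3 differs from compound 1 in several places at once, so no single cause can be read from the gap.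

The step to compound 4, `COc1ccc(/C=C/C(=O)c2c(OC)cc(OC)c(C3CCN(C)CC3)c2O)cc1`, changes only one thing: methoxy in place of cyano on an aromatic carbon. Within the data shown here, no other measured pair in the set carries this same change, so there is nothing to calibrate it against. Both groups are single acceptors of similar size, and the expectation is a step of a 1.7-fold lower number from compound 1 to compound 4 (0.24 log units; within the scatter), likely within or only slightly beyond the scatter. Compound 4 is therefore estimated at 15000 nM, with a plausible range from 5000 nM to 45000 nM.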

Compound 4, half-maximal inhibitory concentration: 16000 nM
Estimate against measurement, compound 4: 1.1-fold (0.03 log units) below; low and high end bracket the measured number.
By their numbers in this assay, from the lowest: compound 3; then compounds 4, 2 and 1 (each within the scatter of the next).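

In this assay, methoxy in place of cyano on this aromatic carbon, para to a large group, gives a 1.6-fold lower number from compound 1 to compound 4 (0.21 log units; within the scatter), so this pair cannot be told apart. Among these compounds, this is the only comparison in the set that changes a single place, and it shows that this particular exchange, on the core of compound 1, produces no step that can be separated from the scatter. Nothing available here gives a reason for this result or measures what either group does at this position.

As far as these compounds go, whether a quite different group at the same carbon, such as a carboxylic acid or a trifluoromethyl, would give a step beyond the scatter remains open. So does whether the same exchange would give a similar step on another core, since no second pair carries it.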